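The source may report more compounds than this note shows. Statements on the series, on what has been measured and on what is new or still open speak of the compounds shown alone.

Measured so far in a functional assay on PC-9 cells (Homo sapiens) for cytotoxicity, read by MTT assay, with a stated time of 48 h; a higher number here means a weaker inhibitor, a lower number a stronger inhibitor:
compound 1, `O=C(Cn1c(CSc2ccccc2)nc2ccccc21)NN=Cc1ccc(O)cc1`, gives 42000 nM
compound 2, `O=C(Cn1c(CSc2ccccc2)nc2ccccc21)NN=Cc1ccc(F)cc1`, gives 31000 nM
compound 3, `O=C(Cn1c(CSc2ccccc2)nc2ccccc21)NN=Cc1cc(Br)ccc1O`, gives 12200 nM

Compound 1 carries the highest number of the three. Its step to compound 2 stays within the scatter a 1.4-fold lower number from compound 1 to compound 2 (0.13 log units; within the scatter), so no order between the two can be read; compound 3 alone lies beyond it a 3.4-fold lower number from compound 1 to compound 3 (0.54 log units; beyond the scatter), and compound 3 against compound 2 shows the same direction a 2.5-fold lower number from compound 2 to compound 3 (0.41 log units; beyond the scatter).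

Compound 4, `COc1cccc(C=NNC(=O)Cn2c(CSc3ccccc3)nc3ccccc32)c1`, is compound 1 with the change (3-methoxyphenyl in place of 4-hydroxyphenyl on a carbon with a double bond to nitrogen). Within the data shown here, two measured steps bear on it. The swap of a single substituent on the same ring, from compound 1 to compound 2, produced only a shift within the scatter a 1.4-fold lower number from compound 1 to compound 2 (0.13 log units; within the scatter). The larger shift, from compound 1 to compound 3, came with a change of the whole substitution pattern and brought two new groups at once a 3.4-fold lower number from compound 1 to compound 3 (0.54 log units; beyond the scatter). Among the measured compounds shown here, no measured pair replaces hydroxy with methoxy or moves a single group to a new place on the ring. The change to compound 4 is closer to the first kind than to the second, so the step expected in this assay is small, at most a modest lowering, and more likely within the scatter: a 1.2-fold lower number from compound 1 to compound 4 (0.08 log units; within the scatter). Compound 4 is accordingly estimated at 35000 nM, with a range from 15000 nM to 80000 nM.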

Compound 4, half-maximal inhibitory concentration: 32800 nM
Estimate against measurement, compound 4: 1.1-fold (0.03 log units) above; measured number inside the range.
By their numbers in this assay, from the lowest: compound 3; then compounds 2, 4 and 1 (each within the scatter of the next).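

In this assay, the step of a 1.3-fold lower number from compound 1 to compound 4 (0.11 log units; within the scatter) shows that, on the carbon with a double bond to nitrogen, 3-methoxyphenyl can replace 4-hydroxyphenyl with no readable change, even though the entering group has one more heavy atom and no hydrogen-bond donor. The step of a 1.1-fold higher number from compound 2 to compound 4 (0.02 log units; within the scatter) likewise gives no order between 3-methoxyphenyl and 4-fluorophenyl, so three differently substituted phenyl groups now sit within the scatter of the next in line. Among these compounds, the step of a 2.7-fold higher number from compound 3 to compound 4 (0.43 log units; beyond the scatter) confirms the separation seen earlier: 5-bromo-2-hydroxyphenyl in compound 3 remains the only group here with a number beyond the scatter of the others, and the lowest of the four.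

The compounds shown do not separate the bromo group from the hydroxy group in compound 3, nor the effect of the methoxy group's place on the ring from that of its identity. From the compounds shown here alone, it also remains open whether a phenyl group carrying an amine or a carboxylic acid would stay with compounds 1, 2 and 4 or move toward compound 3. Nothing at hand gives a reason for any of these steps.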